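Pyrrolidinone series: thiazolyl for trifluoromethyl, cytotoxicity outlook

This account rests on a few compounds, and the source may have more. Where it says the series, first, only, none or still open, it means among the compounds named here.

Measured so far:
- compound 1 `C[C@H]1Cn2ncc(N3CC(c4ccccc4)CC3=O)c2CN1C(=O)Nc1cc(F)c(F)c(F)c1`: 12800 nM
- compound 2 `O=C1CC(C(F)(F)F)CN1c1cnn2c1CN(C(=O)Nc1cc(F)c(F)c(F)c1)C(C1CC1)C2`: 115000 nM

Both numbers come from a toxicity assay on HepG2 2.2.15 cells (Homo sapiens) for cytotoxicity, read by CellTiter-Glo; on this read-out lower numbers stand for higher toxicity in this test and higher numbers for lower toxicity in this test. Of the two measured compounds, compound 2 stands at the higher number, with 115000 nM, and its nearest neighbour compound 1, at 12800 nM, lies well beyond the scatter of this assay. Among the measured compounds shown here, the two compounds differ in more than one place, so no single step links them and the gap is recorded only as what the two values show.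

Compound 3 `O=C1CC(c2nccs2)CN1c1cnn2c1CN(C(=O)Nc1cc(F)c(F)c(F)c1)C(C1CC1)C2` is not yet measured. Relative to compound 2 it carries one change: 1,3-thiazol-2-yl in place of trifluoromethyl on a saturated ring carbon. For the measured compounds named here, no measured pair isolates this change, so the expectation rests on the spread seen between compound 1 and compound 2 alone. A step toward a lower number, beyond the scatter but moderate, is expected as a 2.1-fold lower number from compound 2 to compound 3 (0.32 log units; beyond the scatter). Compound 3 is thus estimated at 55000 nM, with a range from 15000 nM to 200000 nM in this assay.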

Compound 3, half-maximal cytotoxic concentration: 115000 nM
Compound 3: middle estimate off by 2.1-fold (0.32 log units), on the low side; the range from low to high includes it.
By their numbers in this assay, from the lowest: compound 1; then compounds 2 and 3 (each within the scatter of the next).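

In this assay, among the compounds shown here, the swap of trifluoromethyl for 1,3-thiazol-2-yl on the saturated ring carbon gives no change at the digits printed from compound 2 to compound 3 (within the scatter) and is the only single-place comparison available. At this carbon, two ring bonds from the ring nitrogen, a group with no ring and a five-membered aromatic ring with two hydrogen-bond acceptors therefore read alike, with the rest of the molecule held fixed. Nothing measured here explains why the read-out holds across this change.

Still open, going by these compounds, is whether a phenyl at this carbon, on the otherwise unchanged core of compound 2, would read the same. Also open, on these data alone, is whether a carboxylic acid or a primary amine at this carbon would move the read-out in this assay at all.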